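Bromo to Phenyl: Estimating Compound 3

The compounds below may be only part of what the source reports. "The series", "measured", "known", "first", "only" and "open" are said of these compounds alone.

Going by the values given here, in a functional assay (mast cells) for inhibition, with Rattus norvegicus as the target (on this read-out lower numbers stand for an effect already at smaller amounts and higher numbers for an effect only at larger amounts of compound), compound 1 `CC1CC/C(=N\Nc2ccc(Br)cc2)c2ncc(C(=O)O)c(=O)n21` gives 2000 nM, the lowest of the two numbers measured so far. Compound 2 `Cc1cccc(N/N=C2\CCC(C)n3c2ncc(C(=O)O)c3=O)c1` gives 72900 nM; the step of a 36-fold higher number from compound 1 to compound 2 (1.56 log units; beyond the scatter) shows that the aryl group on the amine nitrogen matters greatly. Compound 3 `CC1CC/C(=N\Nc2ccc(-c3ccccc3)cc2)c2ncc(C(=O)O)c(=O)n21` differs from compound 1 by phenyl in place of bromo on an aromatic carbon. Among the compounds with values here, no measured step covers this exact change, and the one known step concerns a different aryl pattern, so it offers only a loose guide. A step of about a 1.5-fold higher number from compound 1 to compound 3 (0.18 log units; within the scatter) is therefore expected, within the scatter. Compound 3 is estimated at 3000 nM, with a range from 500 nM to 20000 nM.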

Compound 3, half-maximal effective concentration: 4400 nM
The estimate for compound 3 lay 1.5-fold (0.17 log units) below the measured number, and the stated range covers the measured number.
By their numbers in this assay, from the lowest: compound 1; then compound 3; then compound 2.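

In this assay, phenyl in place of bromo gives a 2.2-fold higher number from compound 1 to compound 3 (0.34 log units; beyond the scatter) and so counts as a modest change, beyond the scatter. This carbon, para to a large group, therefore accepts a whole six-membered aromatic ring where a single bromine stood, with a far smaller shift than a 36-fold higher number from compound 1 to compound 2 (1.56 log units; beyond the scatter) in the earlier step, which changed the aryl pattern. Nothing available explains the shift. Still open, from the compounds shown here alone, is how other groups on this same carbon would read, such as chloro, methoxy or an amine, and whether any of them would give a lower number than compound 1 does.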